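Benzyl on the amine nitrogen: compound 2 to compound 4

This account rests on a few compounds, and the source may have more. Where it says the series, first, only, none or still open, it means among the compounds named here.

Of the compounds shown here, three sharing one core have been measured in an assay on BTI cells for inhibition of Amine oxidase [flavin-containing] B (Homo sapiens), read by fluorescence, with a stated time of 20 min, tested at 1 uM; a higher number here means more inhibition at the concentration tested (going by the name of the read-out), a lower number less inhibition. Compound 1 `CC1(C)COc2ccccc2C1O` gives 8%. Compound 2 `C#CCNC1c2ccccc2OCC1(C)C` gives 11.6%, and compound 3 `C#CCNC1c2cccc(OC)c2OCC1(C)C` gives 13.8%. Compound 2 thus stands within the scatter of both neighbours: the step from compound 1 to compound 2 is a number 3.6 percentage points higher from compound 1 to compound 2 (within the scatter), and the step from compound 2 to compound 3 is a number 2.2 percentage points higher from compound 2 to compound 3 (within the scatter), neither of which amounts to a real change in this assay.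

Compound 4 `C#CCN(Cc1ccccc1)C1c2ccccc2OCC1(C)C` has not yet been measured. It differs from compound 2 in one place: benzyl in place of hydrogen on an amine nitrogen. No measured step touches this amine nitrogen; the two steps known here, propargylamino in place of hydroxy on a saturated ring carbon and methoxy in place of hydrogen on an aromatic carbon, both stayed within the scatter, so the series so far has shown no change that is larger than the noise.

With nothing pointing in either direction, compound 4 is expected to sit near compound 2, at an estimated 12% with a range from 2% to 26% in this assay. The expected step from compound 2 to compound 4 is therefore a number 0.4 percentage points higher from compound 2 to compound 4 (within the scatter), within the scatter.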

Compound 4, a percentage reported as inhibition, at one concentration (the size of the read-out at that concentration, not a potency): 2.9%
Compound 4: the middle estimate sits 9.1 percentage points above what was measured; the range from low to high includes it.
By their numbers in this assay, from the lowest: compounds 4, 1, 2 and 3 (each within the scatter of the next, the first and the last beyond it).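

Among these compounds, this is the first step that touches the amine nitrogen, and in this assay it reads as a number 8.7 percentage points lower from compound 2 to compound 4 (within the scatter), so even a benzyl group, with its seven carbon atoms and one six-membered aromatic ring, placed on that nitrogen gives no change that can be told from the noise. Taken alone, the result shows that the hydrogen on this amine nitrogen can be replaced by benzyl without a real difference in this read-out at the single concentration tested, and the step joins the two earlier ones in staying within the scatter. The compounds shown offer no measured explanation for this result, and none can be given for what benzyl does or does not do at this nitrogen.

From the compounds shown here alone, it remains open whether a smaller group such as methyl, or a longer chain such as phenethyl, on the same amine nitrogen would move the number beyond the scatter. Also open, going by these compounds, is whether a benzyl carrying a fluorine atom or a methoxy group on its ring would read any differently from the plain benzyl of compound 4 in this assay at this concentration.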